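The compounds below may be only part of what the source reports. "The series", "measured", "known", "first", "only" and "open" are said of these compounds alone.

Compound 2, `COc1ccc(S(=O)(=O)N2CCc3cccc(-c4ccc(C#N)cc4)c32)cc1`, gives the lowest of the three numbers recorded in a functional assay on KB-VIN10 cells (Homo sapiens) for inhibition, with a stated time of 72 h (a higher number here means a weaker inhibitor, a lower number a stronger inhibitor), where compound 2 shows 29.2 nM. Among the compounds with values here, compound 1, `COc1ccc(S(=O)(=O)N2CCc3cccc(-c4ccc([N+](=O)[O-])cc4)c32)cc1`, stands nearest to it, with 51.3 nM in this assay; the step of a 1.8-fold lower number from compound 1 to compound 2 (0.24 log units; within the scatter) is the only single-point change measured here. Within the data shown here, compound 3, `COc1ccc(S(=O)(=O)N2CCc3cccc(-c4c(F)c(F)c(F)c(F)c4F)c32)cc1`, stands furthest away, with 4630 nM in this assay, a number far beyond the scatter from that of compound 2; no single step links the two.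

Compound 4, `COc1ccc(S(=O)(=O)N2CCc3cccc(-c4ccc(F)c(F)c4)c32)cc1`, differs from compound 2 in one place: 3,4-difluorophenyl in place of 4-cyanophenyl on an aromatic carbon. The measured step bears on it only loosely, since it swaps one group for another at the same place without any fluorine entering, and it stayed within the scatter. The values of compounds 2 and 3 show that a ring carrying fluorine can give a much higher number, though that ring carried five. A step upward in this assay is therefore expected, smaller than that gap. Compound 4 is estimated at 250 nM, within 60 nM to 1200 nM, which means an expected step of an 8.6-fold higher number from compound 2 to compound 4 (0.93 log units; beyond the scatter).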

Compound 4, half-maximal inhibitory concentration: 46 nM
Beside the measured number, compound 4's estimate is 5.4-fold (0.74 log units) above it; measured number outside the range, below it.
By their numbers in this assay, from the lowest: compounds 2, 4 and 1 (each within the scatter of the next); then compound 3.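

In this assay, 3,4-difluorophenyl at this aromatic carbon stands level with both earlier para-substituted rings, with a 1.6-fold higher number from compound 2 to compound 4 (0.20 log units; within the scatter) and a 1.1-fold lower number from compound 1 to compound 4 (0.05 log units; within the scatter) as the two new steps. A nitrile or nitro group is therefore not needed on this ring for a number in this range. Fluorine on the ring does not by itself bring a number like that of the pentafluorophenyl compound 3 (4630 nM), and nothing available here explains these numbers.

The compounds shown leave open whether a ring bearing a single fluorine, a methoxy group, an amine or a carboxylic acid would stay in this range. They also leave open how a longer chain in place of the ring would fare at this carbon.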